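The source may hold more compounds than are shown below. What is called first, only, known or untested is meant among the compounds shown, and "the series" means these compounds.

Compound 1 `CCO[C@@H]1O[C@H](CNC(=O)c2ccc(S(N)(=O)=O)cc2)[C@@H](O)[C@H](O)[C@H]1O`: 59.5 h
Compound 2 `CCO[C@@H]1O[C@H](CNC(=O)c2ccc(S(N)(=O)=O)cc2)[C@@H](O)[C@H](O)[C@H]1N`: 58.6 h

For the measured compounds named here, in an ADME assay on microsomes from liver (Mus musculus) for metabolic stability (a lower number here means that the compound disappears faster, a higher number that the compound lasts longer), compound 2 gives 58.6 h, while compound 1 gives 59.5 h; the single step, a 1.0-fold lower number from compound 1 to compound 2 (0.01 log units; within the scatter), is within the scatter, so the two sit level. Compound 3 `CCCO[C@@H]1O[C@H](CNC(=O)c2ccc(S(N)(=O)=O)cc2)[C@@H](O)[C@H](O)[C@H]1N` differs from compound 2 by methyl in place of hydrogen on a saturated chain carbon, two bonds along the chain from an oxygen on a saturated carbon. Going by the values given here, no measured step touches this place, and the only step known, a 1.0-fold lower number from compound 1 to compound 2 (0.01 log units; within the scatter), concerns another position. The step of a 1.2-fold lower number from compound 2 to compound 3 (0.07 log units; within the scatter) is therefore expected to stay within the scatter, in no fixed direction. Compound 3 is expected to give 50 h, between 25 h and 100 h.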

Compound 3, half-life: 64.4 h
For compound 3 the middle estimate is 1.3-fold (0.11 log units) below the measured one, within the range that was stated.
By their numbers in this assay, from the lowest: compounds 2, 1 and 3 (each within the scatter of the next).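

For the compounds shown here, the ethoxy to propoxy change is the first step measured at this position, and in this assay it gives a 1.1-fold higher number from compound 2 to compound 3 (0.04 log units; within the scatter). The added methyl thus leaves the half-life level, so this end of the chain takes one more carbon without a change that can be read. Nothing at hand bears on why the number holds.

Going by these compounds, whether a butoxy chain, a branched isopropoxy group or an amine at the chain end would also hold level stays open. So does whether propoxy behaves alike with hydroxy in place of amino on the ring carbon.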